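Half-life notes on a nonyl ester in the series

A few compounds are considered here, and "the series" means these few. Any claim that something is new, unique, unknown or untested is made for them only; others in the source may bear on it.

Measured in an ADME assay on CCRF-CEM cells (Homo sapiens) for metabolic stability, read by HPLC, at 37 degrees C; on this read-out lower numbers stand for a shorter-lived compound and higher numbers for a longer-lived compound:
- Compound 1 `CCCCCCCC(=O)Oc1ccc(COP(=O)(O)OP(=O)(O)OC[C@H]2O[C@@H](n3cc(C)c(=O)[nH]c3=O)C[C@@H]2N=[N+]=[N-])cc1` gives 1.65 h
- Compound 2 `Cc1ccc(C(=O)Oc2ccc(COP(=O)(O)OP(=O)(O)OC[C@@H]3C=C[C@H](n4cc(C)c(=O)[nH]c4=O)O3)cc2)cc1` gives 14.5 h

Among the compounds with values here, of these two values, compound 2 stands highest at 14.5 h, beyond the scatter from compound 1, its only neighbour. The two differ both in the core and in the ester group, so their gap cannot be assigned to either change.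

Compound 3 `CCCCCCCCCC(=O)Oc1ccc(COP(=O)(O)OP(=O)(O)OC[C@@H]2C=C[C@H](n3cc(C)c(=O)[nH]c3=O)O2)cc1` keeps the core of compound 2 and differs from it by nonyl in place of 4-methylphenyl on a carbonyl carbon. The expectation rests on compound 1, which also has a chain without a ring on that carbonyl carbon and gives 1.65 h. With its different core, this is only a weak guide. A shorter half-life, beyond the scatter, is expected, with an estimated 4.1-fold lower number from compound 2 to compound 3 (0.62 log units; beyond the scatter). For compound 3 the estimated half-life is 3.5 h, with an expected range from 1.2 h to 10 h.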

Compound 3, half-life: 0.833 h
Compound 3: middle estimate off by 4.2-fold (0.62 log units), on the high side; measured number outside the range, below it.
By their numbers in this assay, from the lowest: compounds 3 and 1 (each within the scatter of the next); then compound 2.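

On the shared core, the half-life in this assay is sensitive to the group on this carbonyl carbon: nonyl in place of 4-methylphenyl gives a 17-fold lower number from compound 2 to compound 3 (1.24 log units; beyond the scatter) and is a large step. This pair holds the core constant, so the change can be read on its own, which the gap between compound 1 and compound 2 did not allow. The step removes a six-membered aromatic ring and brings in an open chain at once, and nothing measured here gives a reason for the shorter half-life.

Open, on these data alone, is whether the step follows the loss of the ring or the length of the chain: a butyl group or an unsubstituted phenyl on that carbonyl carbon would separate the two. Also open, as far as these compounds go, is whether the same change moves the half-life as far on the core of compound 1.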